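Triazolyl purine nucleosides: benzyl for phenyl on the triazole

The compounds below may be only part of what the source reports. "The series", "measured", "known", "first", "only" and "open" are said of these compounds alone.

Measured so far:
- compound 1, `CNc1nc(-n2cc(-c3ccccc3)nn2)nc2c1ncn2[C@@H]1O[C@H](CO)[C@@H](O)[C@H]1O` — 14.9 nM
- compound 2, `COc1ccc(Cl)c(CNc2nc(-n3cc(CC4CCCC4)nn3)nc3c2ncn3[C@@H]2O[C@H](CO)[C@@H](O)[C@H]2O)c1` — 18 nM

In an assay on CHO cells for displacement of a labelled ligand from adenosine receptor A3 (Homo sapiens) (on this read-out lower numbers stand for stronger inhibition and higher numbers for weaker inhibition), compound 1 gives 14.9 nM and compound 2 gives 18 nM. Compound 1 has the lowest of the two numbers, but its gap to compound 2 falls within the scatter, so the two cannot be ranked. For the measured compounds named here, compound 2 also differs from compound 1 in more than one position, so no single step is available between the measured compounds.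

Compound 3, `CNc1nc(-n2cc(Cc3ccccc3)nn2)nc2c1ncn2[C@@H]1O[C@H](CO)[C@@H](O)[C@H]1O`, is the unmeasured analogue. It differs from compound 1 by benzyl in place of phenyl on an aromatic carbon, in words: benzyl in place of phenyl on an aromatic carbon. Nothing in the measured pair isolates this change. What can be said is that compound 2, which carries a methylene-linked group on the same ring, sits with compound 1 within the scatter. On this basis the step from compound 1 to compound 3 is expected to be small, most likely none beyond the scatter, with the direction open: a 1.1-fold higher number from compound 1 to compound 3 (0.03 log units; within the scatter). Compound 3 is therefore estimated at 16 nM in this assay, with a range from 5 nM to 50 nM.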

Compound 3, inhibition constant: 9.5 nM
The estimate for compound 3 lay 1.7-fold (0.23 log units) above the measured number; measured number inside the range.
By their numbers in this assay, from the lowest: compounds 3, 1 and 2 (each within the scatter of the next).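

In this assay, for the compounds shown here, benzyl in place of phenyl on an aromatic carbon of the five-membered aromatic ring with 3 nitrogen gives a 1.6-fold lower number from compound 1 to compound 3 (0.20 log units; within the scatter), the first step that isolates a change in one place. At this position, therefore, the aromatic ring of carbon only can be carried as benzyl or as phenyl with no difference that can be told from the scatter, and compound 3 and compound 1 cannot be ranked. No supporting evidence is available to explain this result.

Still open, as far as these compounds go, is whether a group of another kind on the same aromatic carbon, such as an amine, a carboxylic acid or a longer chain such as phenethyl, would move the number beyond the scatter in this assay. Also open, from the compounds shown here alone, is whether benzyl in place of phenyl gives a similar step when the methylamino group of compound 1 gives way to the substituted benzylamino group of compound 2.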